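The source may hold more compounds than are shown below. What is called first, only, known or untested is meant among the compounds shown, and "the series" means these compounds.

Measured compounds:
compound 1, `N#Cc1cccc(COc2ccc(-c3cc(CN4CCN(Cc5ccc(C(F)(F)F)cc5)CC4)no3)cc2)c1`, 100 nM
compound 2, `N#Cc1cccc(COc2ccc(-c3cc(CN4CCN(c5ccc(F)cc5)CC4)no3)cc2)c1`, 1500 nM
compound 3, `N#Cc1cccc(COc2ccc(-c3cc(CN4CCN(Cc5ccc(F)cc5)CC4)no3)cc2)c1`, 1600 nM

In a functional assay on Huh-7 cells (Homo sapiens) for antiproliferative activity, read by sulforhodamine B assay, with a stated time of 72 h (a higher number here means a weaker inhibitor, a lower number a stronger inhibitor), compound 1 gives the lowest of the three numbers. The step of a 15-fold higher number from compound 1 to compound 2 (1.18 log units; beyond the scatter) and the step of a 16-fold higher number from compound 1 to compound 3 (1.20 log units; beyond the scatter) are both large and beyond the scatter, so compound 1 is the strongest inhibitor among the three measured compounds. Compound 2 and compound 3 lie within the scatter of each other, a 1.1-fold higher number from compound 2 to compound 3 (0.03 log units; within the scatter), and no order between them is claimed.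

Compound 4, `Cc1cc(-c2cc(CN3CCN(Cc4ccc(C(F)(F)F)cc4)CC3)no2)ccc1OCc1cccc(C#N)c1`, differs from compound 1 by methyl in place of hydrogen on an aromatic carbon, on an aromatic carbon of a six-membered aromatic ring of carbon only, ortho to a (3-cyanobenzyl)oxy group and meta to a large group. Among the measured compounds shown here, none of the measured steps bears directly on this change: a 15-fold higher number from compound 1 to compound 2 (1.18 log units; beyond the scatter) and a 16-fold higher number from compound 1 to compound 3 (1.20 log units; beyond the scatter) alter the group on the amine nitrogen in the ring or the trifluoromethyl, and the ring that receives the methyl in compound 4 is the same in compound 1, compound 2 and compound 3. For the measured compounds named here, the series gives no measured step for a methyl added there, so no step beyond the scatter in this assay is expected in either direction. For compound 4 the estimate is 100 nM, with a range from 40 nM to 300 nM, that is an expected step of no change at the digits printed from compound 1 to compound 4 (within the scatter).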

Compound 4, half-maximal inhibitory concentration: 600 nM
The estimate for compound 4 lay 6.0-fold (0.78 log units) below the measured number; measured number above the stated range.
By their numbers in this assay, from the lowest: compound 1; then compound 4; then compounds 2 and 3 (each within the scatter of the next).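

In this assay, the ring bearing the (3-cyanobenzyl)oxy group now shows a measured change: methyl in place of hydrogen, ortho to that group and meta to a large group, gives a 6.0-fold higher number from compound 1 to compound 4 (0.78 log units; beyond the scatter). This aromatic carbon is therefore not indifferent to substitution in compound 1, although the step is printed as modest, whereas the change on the far side of the molecule, a 16-fold higher number from compound 1 to compound 3 (1.20 log units; beyond the scatter), is printed as large. The compounds shown include no measurement that accounts for the weaker number of compound 4.

A chloro or methoxy group on the same carbon would help show whether the step is particular to methyl or extends to other groups there. Also open is whether methyl on this carbon would give a similar step with the 4-fluorobenzyl group of compound 3 or the 4-fluorophenyl group of compound 2, as the only methyl step shown has the 4-(trifluoromethyl)benzyl group on the amine nitrogen.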